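Cytotoxicity notes on a benzyl-substituted bicyclic series

The source may report more compounds than this note shows. Statements on the series, on what has been measured and on what is new or still open speak of the compounds shown alone.

Measured in an ADME assay on MDBK cells (Bos taurus) for cytotoxicity; a higher number here means that more compound is tolerated, a lower number that less compound is tolerated:
- compound 1, `N#Cc1ccccc1Cn1ccc2nc(-c3ccccc3)nc-2c1`, gives > 100000 nM, which is a limit of the assay and not a number.
- compound 2, `N#Cc1cccc(Cn2ccc3nc(-c4ccccc4)nc-3c2)c1`, gives > 100000 nM, again a limit of the assay.
- compound 3, `FC(F)(F)c1ccccc1Cn1ccc2nc(-c3ccccc3)nc-2c1`, gives > 100000 nM, also a limit of the assay.

All three compounds share one core and differ only in the benzyl part. Compound 1 and compound 2 have the same atoms joined differently: 3-cyanophenyl in place of 2-cyanophenyl on a saturated chain carbon bound to an aromatic nitrogen. In this assay the step is a step that the two limits leave unreadable from compound 1 to compound 2, unreadable because of the limit of > 100000 nM in this assay, at which 3 of the 3 values shown sit. Compound 1 and compound 3 differ thus: trifluoromethyl in place of cyano on an aromatic carbon. The step is a step that the two limits leave unreadable from compound 1 to compound 3, and it is unreadable for the same reason, since (the limit of > 100000 nM in this assay, at which 3 of the 3 values shown sit).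

Compound 4, `FC(F)(F)c1cccc(Cn2ccc3nc(-c4ccccc4)nc-3c2)c1`, is not yet measured. It differs from compound 2 as follows: trifluoromethyl in place of cyano on an aromatic carbon. This is the same kind of change as that from compound 1 to compound 3, but the place is not the same: there the group sits ortho to a large group, here meta to a large group. Within the scatter the three measured values cannot be ordered, and no trend across the series can be claimed from limits alone.

Compound 4 is expected to behave like the others in this assay, with an estimated step that the limit leaves unreadable from compound 2 to compound 4, resting on the limit shown by compound 2 and on the unreadable step that the two limits leave unreadable from compound 1 to compound 3. The estimate for compound 4 in this assay is 150000 nM, expected to fall between 70000 nM and 400000 nM, most likely reported again only as a limit.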

Compound 4, half-maximal cytotoxic concentration: 98000 nM
Compound 4: the middle estimate sits 1.5-fold (0.18 log units) above what was measured; low and high end bracket the measured number.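

Compound 2 gives > 100000 nM in this assay, which is a limit of the assay and not a number. Trifluoromethyl in place of cyano, meta to a large group, gives an at least 1.0-fold lower number from compound 2 to compound 4 (0.00 log units; that floor lies within the scatter), so this pair shows no change beyond the scatter and fixes no size for the step. The same exchange from compound 1 to compound 3 cannot be read, nor can the other steps among the limits, so the series does not show whether the change behaves alike in the two benzyl settings, and a transfer from one to the other is neither supported nor refuted, because of this: the limit of > 100000 nM in this assay, at which 3 of the 4 values shown sit.

The compounds shown vary only the benzyl part and carry only cyano or trifluoromethyl on it, leaving open whether any substituent on that ring gives a value clearly apart from this limit. An amine or a carboxylic acid in place of those groups, a longer chain in place of the single saturated chain carbon, and any change to the phenyl group on the shared core all remain outside what these compounds can tell.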